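Swapping Phenyl for Pyridine in a Benzylamine Series

The source may report more compounds than this note shows. Statements on the series, on what has been measured and on what is new or still open speak of the compounds shown alone.

Of the compounds shown here, three have so far been tested in a functional assay on HeLa cells (Homo sapiens) for inhibition, with a stated time of 72 h; a higher number here means that more compound is needed for the effect, a lower number that less compound is needed. Compound 2 `COc1cc(CNCc2ccccc2)ccc1OCc1ccc(Cl)nc1` gives 90000 nM, the highest number of the three. Compound 1 `COc1cc(CNCc2ccncc2)ccc1OCc1cccc(F)c1` gives 4800 nM and compound 3 `COc1cc(CNCCNc2ccnc3cc(Cl)ccc23)ccc1OCc1ccc(Cl)nc1` gives 2700 nM; both gaps from compound 2 lie beyond the scatter, so compound 2 is the weakest of the measured set. Compound 4 `COc1cc(CNCc2cccnc2)ccc1OCc1ccc(Cl)nc1` has not yet been measured. It differs from compound 2 in one place: pyridin-3-yl in place of phenyl on a saturated chain carbon bound to an amine nitrogen. For the measured compounds named here, no measured pair shows this exact change on a shared core, so the expectation rests on the measured numbers alone. Compound 4 is expected to give a somewhat lower number than compound 2, a step of a 2.3-fold lower number from compound 2 to compound 4 (0.35 log units; beyond the scatter), with an estimate of 40000 nM and a range from 10000 nM to 150000 nM.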

Compound 4, half-maximal effective concentration: 5000 nM
Beside the measured number, compound 4's estimate is 8.0-fold (0.90 log units) above it, and the stated range ends above it.
By their numbers in this assay, from the lowest: compounds 3, 1 and 4 (each within the scatter of the next); then compound 2.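

In this assay, pyridin-3-yl in place of phenyl on a saturated chain carbon bound to an amine nitrogen gives an 18-fold lower number from compound 2 to compound 4 (1.26 log units; beyond the scatter). For the compounds shown here, the step is large, so exchanging one ring carbon for a nitrogen at this place can change the number strongly, something the earlier compounds, which differ in more than one place, could not show. Nothing available explains why the step is so large. Going by these compounds, it remains open whether pyridin-2-yl or pyrimidin-5-yl at this place would give a similar number.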